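Swapping a Halogenated Ring for a Nitrophenyl

The compounds below may be only part of what the source reports. "The series", "measured", "known", "first", "only" and "open" are said of these compounds alone.

Compound 1 `O=c1cc(Cn2cc(CNS(=O)(=O)c3ccc(F)cc3)nn2)c2ccc(O)cc2o1`: 76700 nM
Compound 2 `O=c1cc(Cn2cc(CNS(=O)(=O)c3ccc(F)cc3Cl)nn2)c2ccc(O)cc2o1`: 74800 nM

Both numbers come from a functional assay on HepG2 cells (Homo sapiens) for inhibition, read by MTT assay, with a stated time of 72 h; a lower number here means a stronger inhibitor, a higher number a weaker inhibitor. Among the measured compounds shown here, compound 2 and compound 1 give values that the step of a 1.0-fold lower number from compound 1 to compound 2 (0.01 log units; within the scatter) shows cannot be told apart, so compound 2 stands level with its only neighbour. Compound 3 `O=c1cc(Cn2cc(CNS(=O)(=O)c3ccc([N+](=O)[O-])cc3)nn2)c2ccc(O)cc2o1` differs from compound 2 by 4-nitrophenyl in place of 2-chloro-4-fluorophenyl on a sulfonyl sulfur. For the measured compounds named here, the single measured step concerns a different exchange, a chloro for a hydrogen, so no measured step speaks directly to a nitro group. Compound 3 is therefore expected to stay close to compound 2, with an estimated step of a 1.1-fold lower number from compound 2 to compound 3 (0.03 log units; within the scatter). The estimate for compound 3 is 70000 nM, expected to lie between 25000 nM and 200000 nM.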

Compound 3, half-maximal inhibitory concentration: > 100000 nM
Compound 3 gave a limit, no number (the forecaster's own chance of this, stated with the estimate: 20%); middle value at least 1.4-fold (0.15 log units) away from the limit.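

In this assay compound 3 gives > 100000 nM, which is a limit of the assay and not a number. Where the earlier chloro exchange had a measured size, this change at the sulfonyl sulfur yields only floors: an at least 1.3-fold higher number from compound 2 to compound 3 (0.12 log units; that floor lies within the scatter) and an at least 1.3-fold higher number from compound 1 to compound 3 (0.11 log units; that floor lies within the scatter). These floors alone cannot show whether 4-nitrophenyl truly weakens inhibition or stays level with the halogenated rings. Still open, as far as these compounds go, is how this assay would read a phenyl ring carrying an amine or a carboxylic acid in place of the nitro group.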